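Swapping an acetylpiperazine for phenyl on a shared core

The compounds below may be only part of what the source reports. "The series", "measured", "known", "first", "only" and "open" are said of these compounds alone.

Of the compounds shown here, two built on the same core have been measured in an assay on isolated protein for displacement of a labelled ligand from 5-hydroxytryptamine receptor 6 (Homo sapiens), read by scintillation counting, with a stated time of 1 h; a higher number here means a weaker inhibitor, a lower number a stronger inhibitor. Compound 1 `O=S(=O)(c1ccccc1)n1ccc2c(O)cccc21` gives 108 nM. Compound 2 `CC(=O)N1CCN(c2cn(S(=O)(=O)c3ccccc3)c3ccccc23)CC1` gives 97 nM, the lower of the two numbers, though its gap to compound 1 lies within the usual scatter of repeated measurements, so the two cannot be told apart on these numbers.

Compound 3 `O=S(=O)(c1ccccc1)n1cc(-c2ccccc2)c2ccccc21` has not yet been measured in this assay. It differs from compound 2 in one place: phenyl in place of 4-acetylpiperazin-1-yl on an aromatic carbon. The change removes the only two hydrogen-bond acceptors outside the shared core and puts a flat, carbon-only ring in place of a saturated ring with two nitrogens.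

Among the measured compounds shown here, nothing measured here tells how this assay responds to such a swap, since no pair of measured compounds differs in just this way. The expectation is a moderate loss of affinity, so the step from compound 2 to compound 3 is estimated as a 3.1-fold higher number from compound 2 to compound 3 (0.49 log units; beyond the scatter). Compound 3 is therefore expected to give about 300 nM, within a range of 60 nM to 1500 nM.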

Compound 3, inhibition constant: 146 nM
Estimate against measurement, compound 3: 2.1-fold (0.31 log units) above; measured number inside the range.
By their numbers in this assay, from the lowest: compounds 2, 1 and 3 (each within the scatter of the next).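

In this assay, swapping 4-acetylpiperazin-1-yl for phenyl on this aromatic carbon gives a 1.5-fold higher number from compound 2 to compound 3 (0.18 log units; within the scatter), so the two compounds cannot be told apart on these numbers. Among the compounds shown here, this is the only measured pair that differs in a single place, and it shows that at this position a saturated ring with two nitrogens and 2 hydrogen-bond acceptors can be replaced by a carbon-only aromatic ring with 0 hydrogen-bond acceptors without a difference that these measurements can resolve. No measurement at hand explains why the two groups read alike.

From the compounds shown here alone, two groups on one carbon say little about the position as a whole, so it remains open whether a free piperazine, a carboxylic acid or a longer alkyl chain placed there would also give a similar number. Going by these compounds, it is also open whether this tolerance would hold if a methylsulfonyl group took the place of the phenylsulfonyl group carried by all three compounds.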